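This account rests on a few compounds, and the source may have more. Where it says the series, first, only, none or still open, it means among the compounds named here.

Compound 1 `CCN(CC)CCCCCCOc1ccc2oc(-c3ccccc3)cc(=O)c2c1` gives 91 nM in an assay on isolated protein (Cavia porcellus) with Sigma non-opioid intracellular receptor 1 (Homo sapiens) as the target, read by radioligand binding; on this read-out higher numbers stand for weaker inhibition and lower numbers for stronger inhibition.
Compound 2 `O=c1cc(-c2cccnc2)oc2ccc(OCCCCCCN3CCC(O)CC3)cc12` gives 194 nM in this assay.

Of these two numbers, compound 2 stands at the higher one; compound 1 sits at a lower number, and that gap lies beyond the usual scatter of repeated measurements. Compound 3 `O=c1cc(C2CCCCC2)oc2ccc(OCCCCCCN3CCC(O)CC3)cc12` has not yet been tested. It differs from compound 2 in one place: cyclohexyl in place of pyridin-3-yl on an aromatic carbon. Among the compounds with values here, no pair of measured compounds shows this exact change, so any expectation rests on the two numbers alone and on the fact that a ring of the same size replaces a ring of the same size. A moderate step toward a lower number is expected, not a large one. The step expected in this assay is a 1.9-fold lower number from compound 2 to compound 3 (0.29 log units; within the scatter). Compound 3 is estimated at 100 nM, with a likely range from 30 nM to 350 nM.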

Compound 3, half-maximal inhibitory concentration: 88 nM
Estimate against measurement, compound 3: 1.1-fold (0.06 log units) above; the range from low to high includes it.
By their numbers in this assay, from the lowest: compounds 3 and 1 (each within the scatter of the next); then compound 2.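

In this assay, the position next to the ring oxygen accepts a change of ring type: cyclohexyl in place of pyridin-3-yl gives a 2.2-fold lower number from compound 2 to compound 3 (0.34 log units; beyond the scatter), a modest step. Within the data shown here, this is the first comparison in which only this group changes, so the difference can be assigned to this position rather than to other parts of the molecules. At this position, neither the ring nitrogen nor the aromatic ring of pyridin-3-yl is needed to reach the lower number, and no measurement shown here accounts for the step.

The change removes the nitrogen and the aromatic character together, so the compounds shown cannot separate the two. On these data alone, how a smaller cyclopropyl ring or an open-chain tert-butyl group would read at this position also remains open.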